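The compounds below may be only part of what the source reports. "The series", "measured", "known", "first", "only" and "open" are said of these compounds alone.

Series notes. Compound 1 `CNC(=O)[C@]12C[C@@H]1[C@@H](n1cnc3c(NCc4cccc(Cl)c4)nc(C#Cc4ccc(F)cc4)nc31)[C@H](O)[C@@H]2O` is recorded at a limit of an assay on isolated protein for binding affinity to adenosine receptor A3 (Homo sapiens) (on this read-out higher numbers stand for weaker inhibition and lower numbers for stronger inhibition), rather than as a number: in this assay compound 1 gives >= 99 nM. Compound 2 `CNC(=O)[C@]12C[C@@H]1[C@@H](n1cnc3c(N[C@@H]4C[C@H]4c4ccc(F)c(F)c4)nc(C#Cc4cccc(F)c4)nc31)[C@H](O)[C@@H]2O` is recorded only as a limit as well, and in this assay compound 2 gives >= 99 nM. Both readings thus sit at the limit of >= 99 nM in this assay, at which 2 of the 2 values shown sit, so compound 1 cannot be placed relative to compound 2; each reading says only that binding is weak.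

Compound 3 `CNC(=O)[C@]12C[C@@H]1[C@@H](n1cnc3c(NCc4cccc(Cl)c4)nc(C#Cc4ccc(F)c(F)c4)nc31)[C@H](O)[C@@H]2O` remains to be measured in this assay. It differs from compound 1 by fluoro in place of hydrogen on an aromatic carbon. Within the data shown here, no measured pair shows the effect of this change, and the readings of compound 1 and compound 2 give no number to move from. A small step, or none beyond the scatter, is expected, and the reading for compound 3 is most likely to be another limit. The expected step is a step that the limit leaves unreadable from compound 1 to compound 3. Compound 3 is estimated at 300 nM, within 100 nM to 3000 nM.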

Compound 3, inhibition constant: >= 99 nM
Compound 3 gave a limit, no number (the forecaster's own chance of this, stated with the estimate: 70%); the middle value is on the limit's open side.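

Compound 3, like compound 1, is recorded only as a limit in this assay, so no step can be read between the two: the limit of >= 99 nM in this assay, at which 3 of the 3 values shown sit.
As far as these compounds go, the effect of going from 4-fluorophenyl to 3,4-difluorophenyl, and any ranking of compound 1, compound 2 and compound 3, remain open.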